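Adding chloro to compound 3

The source may hold more compounds than are shown below. What is called first, only, known or untested is meant among the compounds shown, and "the series" means these compounds.

In an ADME assay on HeLa cells (Homo sapiens) for cytotoxicity, read by XTT assay, with a stated time of 3 days (on this read-out higher numbers stand for lower toxicity in this test and lower numbers for higher toxicity in this test), compound 1 `Clc1ccc2c(c1)C=C(/C=C/c1ccccn1)CO2` gives only a limit, > 50000 nM. Compound 2 `Clc1ccc2c(c1)C=C(/C=C/c1cccnc1)CO2` reads 37500 nM. Compound 3 `C1=C(/C=C/c2ccncc2)COc2ccccc21` reads 75000 nM, which lies within the scatter of compound 2.

Compound 4 `Clc1ccc2c(c1)C=C(/C=C/c1ccncc1)CO2` differs from compound 3 by chloro in place of hydrogen on an aromatic carbon. Within the data shown here, the only measured step, an at least 1.3-fold lower number from compound 1 to compound 2 (0.12 log units; that floor lies within the scatter), exchanges pyridin-2-yl for pyridin-3-yl with chloro present throughout, so no measured step tests the chloro change itself. Compound 2 also carries chloro and gives 37500 nM, which points to no large change in this assay. The expected change, a 1.7-fold lower number from compound 3 to compound 4 (0.22 log units; within the scatter), stays within the scatter. For compound 4 the estimated value is 45000 nM, with an expected range of 18000 nM to 100000 nM.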

Compound 4, half-maximal cytotoxic concentration: 75000 nM
Estimate against measurement, compound 4: 1.7-fold (0.22 log units) below, and the stated range covers the measured number.
By their numbers in this assay, from the lowest: compounds 2, 3 and 4 (each within the scatter of the next).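

Chloro in place of hydrogen on this aromatic carbon, meta to a fused ring and para to a fused ring, now has a measured step of its own in this assay (no change at the digits printed from compound 3 to compound 4 (within the scatter)), and it lies within the scatter. With chloro present, pyridin-4-yl in place of pyridin-3-yl also stays within the scatter (a 2.0-fold higher number from compound 2 to compound 4 (0.30 log units; within the scatter)). Compound 1 gives only a limit, so its step to compound 4 cannot be read: the limit of > 50000 nM in this assay, at which 1 of the 4 values shown sits.

On these data alone, whether methoxy or an amine on this aromatic carbon would move the number beyond the scatter remains open.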